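Bromo for pentyl on the anilide ring of compound 1

The compounds below may be only part of what the source reports. "The series", "measured", "known", "first", "only" and "open" are said of these compounds alone.

Measured compounds:
compound 1 `CCCCCc1ccc(NS(=O)(=O)c2ccc(N3CCNC3=O)cc2)cc1` — > 1000 nM
compound 2 `Cc1ccccc1NS(=O)(=O)c1ccc(N2CCNC2=O)cc1` — 280 nM
compound 3 `COc1ccccc1NS(=O)(=O)c1ccc(N2CCNC2=O)cc1` — 770 nM

The three measured compounds share one core and differ only in the substituent on the anilide ring. Compound 2 carries a methyl group and in a functional assay on MCF7 cells (Homo sapiens) for antiproliferative activity, read by sulforhodamine B assay, with a stated time of 48 h (a lower number here means a stronger inhibitor, a higher number a weaker inhibitor), compound 2 gives 280 nM. Within the data shown here, compound 3 carries a methoxy group in place of methyl and gives 770 nM; the step of a 2.8-fold higher number from compound 2 to compound 3 (0.44 log units; beyond the scatter) is the only change that has been followed with two full numbers. Compound 1, with a pentyl chain, stands apart: its result is a limit of the assay, > 1000 nM, and no number is available for it (the limit of > 1000 nM in this assay, at which 1 of the 3 values shown sits).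

The compound now in question is compound 4 `O=C1NCCN1c1ccc(S(=O)(=O)Nc2ccc(Br)cc2)cc1`. It differs from compound 1 as follows: bromo in place of pentyl on an aromatic carbon. Among the measured compounds shown here, no measured step covers this exchange; the single step from compound 2 to compound 3 concerns a different position and a different pair of groups, so it gives no direct guide to size or direction. The only bearing is that the compounds with small substituents, compound 2 and compound 3, fall within the measured range, while compound 1 with its five-carbon chain does not.

Compound 4 is therefore expected to return a number rather than a limit, estimated at 600 nM with a range from 200 nM to 2000 nM. Against compound 1 this would be a step of an at least 1.6-fold lower number from compound 1 to compound 4 (0.22 log units; that floor lies within the scatter), though with compound 1 at a limit only its lower bound is known.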

Compound 4, half-maximal inhibitory concentration: 240 nM
Compound 4: middle estimate off by 2.5-fold (0.40 log units), on the high side; measured number inside the range.
By their numbers in this assay, from the lowest: compounds 4 and 2 (each within the scatter of the next); then compound 3. At a limit, above all of these: compound 1.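

Bromo in place of pentyl on an aromatic carbon, para to a large group, gives an at least 4.1-fold lower number from compound 1 to compound 4 (0.61 log units; beyond the scatter), the first step at this place that reaches a measured number in this assay. Compound 1 stays a limit and not a number, so that step has only a floor: the limit of > 1000 nM in this assay, at which 1 of the 4 values shown sits. The 4-bromophenyl group on the sulfonamide nitrogen also gives a 3.2-fold lower number from compound 3 to compound 4 (0.51 log units; beyond the scatter), whereas a 1.2-fold lower number from compound 2 to compound 4 (0.07 log units; within the scatter) stays within the scatter, so the 4-bromophenyl and 2-methylphenyl groups cannot be told apart here.

As far as these compounds go, whether a shorter chain such as ethyl, or an amine or a carboxylic acid, at this place would behave like bromo or like pentyl stays open. From the compounds shown here alone, the effect of place apart from the group also stays open, as the 2-methylphenyl and 4-bromophenyl groups differ in both.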